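This account rests on a few compounds, and the source may have more. Where it says the series, first, only, none or still open, it means among the compounds named here.

Measured in a functional assay on Vero cells (Chlorocebus sabaeus) for inhibition (a lower number here means a stronger inhibitor, a higher number a weaker inhibitor), all three as limits:
- compound 1 `Clc1ccc(Cn2cnc3c(-c4ccco4)ncnc32)cc1`: > 62.5 ug/mL
- compound 2 `Clc1ccc(Cn2cnc3c(-c4ccco4)ncnc32)cc1Cl`: > 10 ug/mL
- compound 3 `Fc1ccccc1Cn1cnc2c(-c3ccco3)ncnc21`: > 10 ug/mL

Compound 1 has no number, only (the limit of > 62.5 ug/mL in this assay, at which 1 of the 3 values shown sits). Compound 2 and compound 3 have no number either, and share (the limit of > 10 ug/mL in this assay, at which 2 of the 3 values shown sit). Among the compounds with values here, no compound in this small set has yet given a readable value in this assay, so compound 1 cannot be ranked against the others.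

The next compound, compound 4 `CCOc1ccc(Cn2cnc3c(-c4ccco4)ncnc32)cc1`, carries ethoxy in place of chloro on an aromatic carbon.

Within the data shown here, two measured steps bear on this change. Among the measured compounds shown here, the first is a step that the two limits leave unreadable from compound 1 to compound 2, which adds a chloro group. The second is a step that the two limits leave unreadable from compound 1 to compound 3, which replaces the 4-chlorophenyl with 2-fluorophenyl. For the measured compounds named here, neither gives a size or a direction, and the set holds no measured step that starts from a real number.

With nothing to point either way, no step beyond the scatter is expected in this assay. The estimated move is an at least 1.5-fold lower number from compound 1 to compound 4 (0.19 log units; that floor lies within the scatter), and this estimate carries little weight. Another limit is the most likely report, rather than a number.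

For compound 4 the expected value is 40 ug/mL, with an estimated range of 10 ug/mL to 100 ug/mL.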

Compound 4, half-maximal inhibitory concentration: 37.4 ug/mL
Estimate against measurement, compound 4: 1.1-fold (0.03 log units) above, within the range that was stated.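

In this assay, within the data shown here, compound 4 gives 37.4 ug/mL, the first readable number in this set, so a compound with ethoxy at this place on the six-membered aromatic ring of carbon only, para to a large group, reads as a value rather than a limit. The change from chloro to ethoxy gives an at least 1.6-fold lower number from compound 1 to compound 4 (0.22 log units; that floor lies within the scatter); this is a floor and not a measured size, and the real step may be larger. Compound 1 enters this comparison only as a limit, not as a number: the limit of > 62.5 ug/mL in this assay, at which 1 of the 4 values shown sits.

Among these compounds, the steps from compound 1 to compound 2 and to compound 3 cannot be read, so compound 4 remains the only compound in the set that anchors the series to a number. Going by these compounds, whether that number belongs to ethoxy alone stays open: methoxy, a longer chain such as butoxy, or an amine at the same place would show whether the read-out holds, and any of these would give a step starting from the real value of compound 4 rather than from a limit.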